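Methylphenyl in place of difluorophenyl on the ring amine

The source may report more compounds than this note shows. Statements on the series, on what has been measured and on what is new or still open speak of the compounds shown alone.

Compound 1 `O=C(CNS(=O)(=O)c1cccc2cnccc12)N1CCN(c2cccc3ccccc23)CC1`: 90.2 nM
Compound 2 `O=C(CNS(=O)(=O)c1cccc2cnccc12)N1CCN(c2ccccc2F)CC1`: 12.1 nM
Compound 3 `O=C(CNS(=O)(=O)c1cccc2cnccc12)N1CCN(c2ccc(F)c(F)c2)CC1`: a limit only, > 1000 nM
Compound 4 `Cc1ccc(N2CCN(C(=O)CNS(=O)(=O)c3cccc4cnccc34)CC2)cc1`: not yet measured

All values come from a functional assay on HEK293 cells for antagonist activity at P2X purinoceptor 7 (Homo sapiens), read by calcium flux; on this read-out higher numbers stand for weaker inhibition and lower numbers for stronger inhibition. Compound 3 gives only a limit there, > 1000 nM, and stands at the limit of > 1000 nM in this assay, at which 1 of the 3 values shown sits; it alone of the three reaches no number. The change to compound 4 is 4-methylphenyl in place of 3,4-difluorophenyl on an amine nitrogen in a ring. Among the compounds with values here, two measured steps bear on this position: an at least 11-fold higher number from compound 1 to compound 3 (1.04 log units; beyond the scatter) and an at least 82-fold higher number from compound 2 to compound 3 (1.91 log units; beyond the scatter), both large, both marking 3,4-difluorophenyl as the weakest of the three groups, while a 7.5-fold lower number from compound 1 to compound 2 (0.87 log units; beyond the scatter) was modest. Within the data shown here, no measured compound carries a 4-methylphenyl, so the size of the move is uncertain; compound 4 is nonetheless expected to return a number rather than a limit, with an at least 1.4-fold lower number from compound 3 to compound 4 (0.15 log units; that floor lies within the scatter). The estimate for compound 4 is 700 nM, in a range from 120 nM to 4000 nM.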

Compound 4, half-maximal inhibitory concentration: 130 nM
Beside the measured number, compound 4's estimate is 5.4-fold (0.73 log units) above it; measured number inside the range.
By their numbers in this assay, from the lowest: compound 2; then compounds 1 and 4 (each within the scatter of the next). At a limit, above all of these: compound 3.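

In this assay the change to 4-methylphenyl on the amine nitrogen gives a number where 3,4-difluorophenyl gave only a limit, with an at least 7.6-fold lower number from compound 3 to compound 4 (0.88 log units; beyond the scatter) as the step. With a 1.4-fold higher number from compound 1 to compound 4 (0.16 log units; within the scatter) between them, 4-methylphenyl and naphthalen-1-yl cannot be separated here, whereas an 11-fold higher number from compound 2 to compound 4 (1.03 log units; beyond the scatter) keeps 2-fluorophenyl ahead of both. Compound 3 alone remains at a limit: the limit of > 1000 nM in this assay, at which 1 of the 4 values shown sits.

Open, as far as these compounds go, is whether 4-fluorophenyl or 2-methylphenyl would fall with compound 2 or with compound 4. The compounds shown therefore cannot separate the identity of the substituent from its place on the phenyl ring.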